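Bis-indolylmethanes with para-halogen: potency against A549 cells

The compounds below may be only part of what the source reports. "The series", "measured", "known", "first", "only" and "open" are said of these compounds alone.

Measured so far:
Compound 1, `O=[N+]([O-])c1ccc2[nH]cc(C(c3ccc(Cl)cc3)c3c[nH]c4ccc([N+](=O)[O-])cc34)c2c1`, in a functional assay on A549 cells (Homo sapiens) for inhibition, read by MTT assay, with a stated time of 48 h (on this read-out higher numbers stand for weaker inhibition and lower numbers for stronger inhibition), gives > 100000 nM, which is a limit of the assay.
Compound 2, `O=[N+]([O-])c1ccc2[nH]cc(C(c3ccc(Br)cc3)c3c[nH]c4ccc([N+](=O)[O-])cc34)c2c1`, in this assay gives > 100000 nM, which is a limit of the assay.
Compound 3, `N#Cc1ccc2[nH]cc(C(c3ccc(Cl)cc3)c3c[nH]c4ccc(C#N)cc34)c2c1`, in this assay gives > 100000 nM, which is a limit of the assay.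

Going by the values given here, every value so far sits at the limit of > 100000 nM in this assay, at which 3 of the 3 values shown sit. As far as these compounds go, the change bromo in place of chloro on an aromatic carbon gives the step that the two limits leave unreadable from compound 1 to compound 2, so its size is unknown. The difference between the core of compound 1 and the core of compound 3 is not broken down here.

Compound 4, `N#Cc1ccc2[nH]cc(C(c3ccc(Br)cc3)c3c[nH]c4ccc(C#N)cc34)c2c1`, is not yet measured. It differs from compound 3 by bromo in place of chloro on an aromatic carbon, the same change as between compound 1 and compound 2, at the same place. Because compound 1 and compound 2 both sit at the limit of > 100000 nM in this assay, at which 3 of the 3 values shown sit, no measured size is available to carry over. The expected step that the limit leaves unreadable from compound 3 to compound 4 is therefore taken as flat, a guess rather than a reading. Compound 4 is expected to give 150000 nM, between 40000 nM and 600000 nM, and most likely to be reported again only as a limit.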

Compound 4, half-maximal inhibitory concentration: > 100000 nM
Compound 4 was reported as a limit (the forecaster's own chance of this, stated with the estimate: 85%); the middle value lies beyond the limit too.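

Going by these compounds alone, no step from compound 3 to compound 4 can be read, because both values are limits: the limit of > 100000 nM in this assay, at which 4 of the 4 values shown sit. The compounds shown leave open whether bromo in place of chloro on an aromatic carbon changes inhibition at all.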